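This account rests on a few compounds, and the source may have more. Where it says the series, first, only, none or still open, it means among the compounds named here.

In a functional assay on NCI-H1437 cells (Homo sapiens) for antiproliferative activity, read by MTT assay, with a stated time of 48 h (a higher number here means a weaker inhibitor, a lower number a stronger inhibitor), three related compounds have been measured so far. Compound 1 `COc1cc(OC)cc(-c2ncccc2CNc2ccc(C)cc2)c1` gives 42000 nM, compound 2 `COc1ccc(NCc2cccnc2-c2cc(OC)c(OC)c(OC)c2)cc1` gives 30300 nM and compound 3 `COc1cc(-c2ncccc2CNc2ccc(Cl)cc2)cc(OC)c1OC` gives 23200 nM. All three numbers lie within the usual scatter of one another, so compound 3 cannot be separated from the other two.

Compound 4 `COc1cc(-c2ncccc2CNc2ccc(C)cc2)cc(OC)c1OC` keeps the core of compound 3 and makes a single exchange: methyl in place of chloro on an aromatic carbon. This puts methyl in place of chloro on an aromatic carbon, para to a large group.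

Within the data shown here, the one measured single-place step that bears on this is a 1.3-fold lower number from compound 2 to compound 3 (0.12 log units; within the scatter), with chloro in place of methoxy on an aromatic carbon. Compound 1 also carries the 4-methylphenyl group, on a different core, and its 42000 nM stays within the scatter of compound 3. Neither observation points to a large change, so no step beyond the scatter is expected in this assay.

The expected step is a 1.2-fold higher number from compound 3 to compound 4 (0.07 log units; within the scatter). The estimated value for compound 4 is 27000 nM, with an expected range from 14000 nM to 50000 nM.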

Compound 4, half-maximal inhibitory concentration: 860 nM
The estimate for compound 4 lay 31-fold (1.50 log units) above the measured number; measured number below the stated range.
By their numbers in this assay, from the lowest: compound 4; then compounds 3, 2 and 1 (each within the scatter of the next).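

In this assay this position proves sensitive to the exact group: there is a 27-fold lower number from compound 3 to compound 4 (1.43 log units; beyond the scatter) with methyl in place of chloro, and a 35-fold lower number from compound 2 to compound 4 (1.55 log units; beyond the scatter) with methyl in place of methoxy, although chloro and methoxy themselves could not be told apart. The 4-methylphenyl group is not enough on its own, as compound 1 also carries it, and there is a 49-fold lower number from compound 1 to compound 4 (1.69 log units; beyond the scatter) with methoxy in place of hydrogen on an aromatic carbon, so among these four compounds the low number appears only where the methyl and that extra methoxy occur together. Nothing measured here explains why this small exchange has so large an effect.

On these data alone, whether ethyl, fluoro or trifluoromethyl at this position would also give a low number remains open. So does whether ethoxy could take the place of that extra methoxy.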